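The compounds below may be only part of what the source reports. "The series", "measured", "known", "first", "only" and "open" are said of these compounds alone.

Measured compounds:
compound 1 `COC(=O)Nc1nc(CN=C=S)cs1` — 3200 nM
compound 2 `COC(=O)Nc1nc(CN=C=S)c[se]1` — 22000 nM

In a functional assay on L1210 cells (Mus musculus) for inhibition (a lower number here means a stronger inhibitor, a higher number a weaker inhibitor), compound 1 gives 3200 nM. Compound 2, which carries selenium in place of sulfur in the aromatic ring, gives 22000 nM in this assay. Compound 1 thus stands at the lowest of the two numbers shown, and the gap to compound 2 lies beyond the scatter of repeated measurements. Within the data shown here, no single-point step between measured compounds has been worked out for this pair, so only the two values themselves are available.

Compound 3 `COC(=O)Nc1nc(CN=C=[Se])cs1` has not been measured. It differs from compound 1 by a group of 3 heavy atoms (1 carbon, 1 nitrogen, 1 selenium; no ring) in place of a group of 3 heavy atoms (1 carbon, 1 nitrogen, 1 sulfur; no ring), on a saturated chain carbon bound to an aromatic carbon. Among the measured compounds shown here, the only comparable sulfur-to-selenium exchange, that between compound 1 and compound 2, sits in the ring and not on the chain, so it gives no direct guide. The expectation for this assay is a move toward a weaker inhibitor, of moderate size, with an outcome inside the scatter also possible. The expected step from compound 1 to compound 3 is a 2.2-fold higher number from compound 1 to compound 3 (0.34 log units; beyond the scatter). Compound 3 is estimated at 7000 nM, with a range from 1800 nM to 28000 nM.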

Compound 3, half-maximal inhibitory concentration: 7600 nM
Estimate against measurement, compound 3: 1.1-fold (0.04 log units) below; the range from low to high includes it.
By their numbers in this assay, from the lowest: compound 1; then compound 3; then compound 2.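

In this assay, placing the group containing selenium in place of the group containing sulfur, on a saturated chain carbon bound to an aromatic carbon, gives a 2.4-fold higher number from compound 1 to compound 3 (0.38 log units; beyond the scatter) and so shows that this position responds to the exchange. The change is modest, and inhibition remains measurable with selenium on the chain; the same element exchange in the ring had already separated compound 1 at 3200 nM from compound 2 at 22000 nM, so both exchanges from compound 1 shown here lead to a higher number, with no compound shown going against this across these two cases. No available measurement bears on what lies behind the step at this position.

As far as these compounds go, whether an amine or a carboxylic acid at this position would retain inhibition, and how a longer chain between the aromatic carbon and the group would behave, remains open. Among these compounds, also open is how selenium in both the ring and the chain group would read out in this assay, since each exchange is seen only on its own.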